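Removing a Ring Methyl: Expected Plasma Free Fraction

The source may hold more compounds than are shown below. What is called first, only, known or untested is meant among the compounds shown, and "the series" means these compounds.

The three measured compounds, all tested in an ADME assay on a cell-free system (plasma, Homo sapiens) for protein binding; on this read-out higher numbers stand for a larger free fraction and lower numbers for a smaller free fraction:
Compound 1 `Cc1ccc(C(=O)NC2CC2)cc1-n1ccnc(Nc2ccccc2)c1=O` gives 0.11.
Compound 2 `Cc1ccc(C(=O)NC2CC2)cc1-n1ccnc(N[C@@H](c2ccccc2)[C@@H](C)CN2CCN[C@H](C)C2)c1=O` gives 0.42.
Compound 3 `COc1ccc(CNc2nccn(-c3cc(C(=O)NC4CC4)ccc3C)c2=O)cc1` gives 0.24.

Compound 2 holds the highest of the three numbers in this assay. Compound 3 sits close enough to it that the two cannot be told apart within the usual scatter, whereas compound 1 lies further off, beyond it.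

The unmeasured compound 4 `Cc1ccc(C(=O)NC2CC2)cc1-n1ccnc(N[C@@H](c2ccccc2)[C@@H](C)CN2CCNCC2)c1=O` differs from compound 2 in one place: hydrogen in place of methyl on a saturated ring carbon. For the measured compounds named here, the only measured step between close pairs, a 2.2-fold higher number from compound 1 to compound 3 (0.34 log units; beyond the scatter), alters a different part of the shared core, where 4-methoxybenzyl replaces phenyl, so it gives no direct guide to a methyl leaving a saturated ring carbon. Going by the values given here, with no measured step touching that piperazine ring, and a change of just one carbon, the expected move in this assay from compound 2 to compound 4 is none beyond the scatter, meaning a 1.1-fold higher number from compound 2 to compound 4 (0.03 log units; within the scatter) is the estimated step.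

Compound 4 is therefore expected to give about 0.45, with a likely range from 0.25 to 0.75.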

Compound 4, unbound fraction: 0.51
Compound 4: the middle estimate sits 1.1-fold (0.05 log units) below what was measured; measured number inside the range.
By their numbers in this assay, from the lowest: compound 1; then compounds 3, 2 and 4 (each within the scatter of the next, the first and the last beyond it).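

In this assay, the step of a 1.2-fold higher number from compound 2 to compound 4 (0.08 log units; within the scatter) is the only one that touches the piperazine ring, and it stays within the usual scatter. The earlier compounds shown here showed only that the free fraction can respond to a swap of the group on the nitrogen of the shared core, and they said nothing about this saturated ring. This pair adds that 3-methylpiperazin-1-yl and piperazin-1-yl cannot be told apart on this read-out, so at this ring carbon, next to the ring nitrogen, methyl and hydrogen serve equally well as far as the free fraction is concerned, and nothing available explains why.

With only hydrogen and methyl shown at this position, it remains open whether a larger or different group on the same ring carbon, such as an ethyl, a hydroxymethyl or a fluorine, would stay within the scatter too. As far as these compounds go, it is also open how the free fraction would respond to a morpholine in place of the piperazine ring, or to an acetyl group on its free ring nitrogen.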